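The compounds below may be only part of what the source reports. "The series", "measured", "known", "first", "only" and "open" are said of these compounds alone.

Measured so far in a physicochemical assay for solubility, measured as kinetic solubility, at pH 7.4; a higher number here means a more soluble compound, a lower number a less soluble compound
- compound 1 `Cc1cccc(C(=O)N[C@@H]2C(=O)Nc3c(c(C)nn3C3CCCC3)[C@@H]2c2ccc(F)cc2)c1` with 17100 nM
- compound 2 `CCN1C(=O)[C@@H](NC(=O)c2cccc(C)c2)[C@@H](c2ccc(F)cc2)c2c(C)nn(C3CC3)c21` with 46100 nM

Of these two numbers, compound 1 holds the lower, and compound 2 stands above it by more than the usual scatter. The two compounds differ in more than one place, so their gap says little about any single change.

The next compound, compound 3 `Cc1cccc(C(=O)N[C@@H]2C(=O)Nc3c(c(C)nn3-c3ccccc3)[C@@H]2c2ccc(F)cc2)c1`, has not yet been measured. It carries phenyl in place of cyclopentyl on an aromatic nitrogen of the core of compound 1 (phenyl in place of cyclopentyl on an aromatic nitrogen). Among the compounds with values here, no measured pair shows this change, so the expectation rests on the structural change alone: a small downward step in this assay, probably not beyond the scatter. The expected move is a 1.6-fold lower number from compound 1 to compound 3 (0.19 log units; within the scatter) as an estimated step. For compound 3 the estimated value is 11000 nM, expected to lie between 3000 nM and 35000 nM.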

Compound 3, solubility: 5500 nM
Beside the measured number, compound 3's estimate is 2.0-fold (0.30 log units) above it; the range from low to high includes it.
By their numbers in this assay, from the lowest: compound 3; then compound 1; then compound 2.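

In this assay, within the data shown here, phenyl in place of cyclopentyl on the aromatic nitrogen gives a 3.1-fold lower number from compound 1 to compound 3 (0.49 log units; beyond the scatter) and provides the first comparison here of compounds that differ in one place. The step shows that the read-out responds to the group at this position on the shared core. Here, a six-membered aromatic ring of carbon only goes with a lower number than a five-membered non-aromatic ring of carbon only. No measured property is available here to explain this step.

Because ring size and aromatic character change together in this single pair, the compounds shown cannot separate the two. From the compounds shown here alone, how a cyclohexyl group, which would keep the ring non-aromatic at the size of phenyl, or a phenyl ring carrying an amine would compare at this nitrogen remains open.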